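A few compounds are considered here, and "the series" means these few. Any claim that something is new, unique, unknown or untested is made for them only; others in the source may bear on it.

Compound 2 `Brc1cccc(C2=NCCCC2)c1` gives 29.8 nM in an assay on HEK293 cells for displacement of a labelled ligand from Neuronal acetylcholine receptor; alpha3/beta4 (Homo sapiens), read by radioligand binding, with a stated time of 5 min (on this read-out lower numbers stand for stronger inhibition and higher numbers for weaker inhibition), the lowest of the three numbers available. Its nearest neighbour is compound 3 `Brc1cc(Br)cc(C2=NCCCC2)c1`, which gives 70.8 nM; the step of a 2.4-fold higher number from compound 2 to compound 3 (0.38 log units; beyond the scatter) is described as modest, and its structural content is an added bromo on an aromatic carbon. Among the compounds with values here, the furthest is compound 1 `OCc1cc(F)cc(C2=NCCCC2)c1`, which gives 80 nM in this assay; no single-point step links it to compound 2.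

Compound 4 `Oc1cccc(C2=NCCCC2)c1` is reached from compound 2 by hydroxy in place of bromo on an aromatic carbon. Within the data shown here, none of the measured steps tests this exact exchange: the only step, from compound 2 to compound 3, concerns a second bromo, and compound 1 carries a hydroxymethyl and a fluoro rather than a hydroxy. What the measured compounds do show is that the bromo-bearing compound 2 sits lowest, so a change that removes that bromo is expected to give a somewhat higher number, with a wide range. The estimate for compound 4 is 120 nM, between 35 nM and 450 nM, meaning an expected step of a 4.0-fold higher number from compound 2 to compound 4 (0.60 log units; beyond the scatter).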

Compound 4, inhibition constant: 680 nM
Compound 4: middle estimate off by 5.7-fold (0.75 log units), on the low side; measured number outside the range, above it.
By their numbers in this assay, from the lowest: compound 2; then compounds 3 and 1 (each within the scatter of the next); then compound 4.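

In this assay the position on the aromatic carbon meta to a group of 6 heavy atoms proves sensitive to what stands on it: hydroxy in place of bromo gives a 23-fold higher number from compound 2 to compound 4 (1.36 log units; beyond the scatter), a large step towards weaker inhibition. Within the data shown here, the only earlier single-place step, a 2.4-fold higher number from compound 2 to compound 3 (0.38 log units; beyond the scatter), is modest and adds a second bromo while keeping the first, so it gave no sign that replacing the bromo at this position could cost this much. No measurement at hand bears on why the exchange has so large an effect.

The compounds shown leave open whether the step reflects the loss of bromo or the arrival of hydroxy. A chloro, a methoxy or an amine on this same aromatic carbon would help to separate the two.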